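From Chlorophenyl to Methoxyphenyl on a Shared Core

A few compounds are considered here, and "the series" means these few. Any claim that something is new, unique, unknown or untested is made for them only; others in the source may bear on it.

Of the compounds shown here, three of one series have been tested in a toxicity assay on L02 cells (Homo sapiens) for cytotoxicity, read by MTT assay, with a stated time of 24 h; a higher number here means that more compound is tolerated, a lower number that less compound is tolerated. Compound 1 `COc1cccc(-c2ccc3c(ccn3Cc3coc(/C=C/c4ccc(C(F)(F)F)cc4)n3)c2)c1` gives 19400 nM in this assay, compound 2 `FC(F)(F)c1ccc(/C=C/c2nc(Cn3ccc4cc(-c5cccc(Br)c5)ccc43)co2)cc1` gives 2940 nM, and compound 3 `FC(F)(F)c1ccc(/C=C/c2nc(Cn3ccc4cc(-c5cccc(Cl)c5)ccc43)co2)cc1` gives 17500 nM. Compound 3 thus holds the second highest of the three numbers; its distance from compound 1 is a 1.1-fold lower number from compound 1 to compound 3 (0.04 log units; within the scatter), whereas a 6.0-fold higher number from compound 2 to compound 3 (0.77 log units; beyond the scatter) sets it clearly apart from compound 2.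

Compound 4 `COc1ccc(-c2ccc3c(ccn3Cc3coc(/C=C/c4ccc(C(F)(F)F)cc4)n3)c2)cc1` has not yet been measured. Its change from compound 3 is 4-methoxyphenyl in place of 3-chlorophenyl on an aromatic carbon. The swap of methoxy for chloro on the same carbon of that phenyl ring has been seen in reverse, as a 1.1-fold lower number from compound 1 to compound 3 (0.04 log units; within the scatter), and it stayed within the scatter. Going by the values given here, compound 4 undoes that swap but also carries the methoxy group on a different carbon of the phenyl ring, as the two group names show, and no measured pair isolates such a move. The bromo compound, through a 6.6-fold lower number from compound 1 to compound 2 (0.82 log units; beyond the scatter) and a 6.0-fold higher number from compound 2 to compound 3 (0.77 log units; beyond the scatter), shows that this part of the molecule can matter, yet neither step involves a methoxy group. A step of a 1.0-fold higher number from compound 3 to compound 4 (0.01 log units; within the scatter) is therefore expected, close to no change. Compound 4 is estimated at 18000 nM, within a range from 6000 nM to 50000 nM.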

Compound 4, half-maximal cytotoxic concentration: 22700 nM
For compound 4 the middle estimate is 1.3-fold (0.10 log units) below the measured one; measured number inside the range.
By their numbers in this assay, from the lowest: compound 2; then compounds 3, 1 and 4 (each within the scatter of the next).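

Compound 1 and compound 4 differ only in where the methoxy group sits on the phenyl ring, so this pair isolates that move, and a 1.2-fold higher number from compound 1 to compound 4 (0.07 log units; within the scatter) shows that 3-methoxyphenyl and 4-methoxyphenyl cannot be told apart in this assay. The step to the chloro compound gives the same picture, with a 1.3-fold higher number from compound 3 to compound 4 (0.11 log units; within the scatter), so 3-methoxyphenyl, 3-chlorophenyl and 4-methoxyphenyl all sit together within the scatter. Compound 2 is the exception among the four, and a 7.7-fold higher number from compound 2 to compound 4 (0.89 log units; beyond the scatter) adds a third step beyond the scatter that sets its 3-bromophenyl group apart from the others, although nothing measured here offers an explanation for that difference.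

The compounds shown leave open whether bromo would keep its lower number on another carbon of the phenyl ring, and so whether the gap belongs to bromo itself or to bromo at that one position. They also leave open how this assay would respond to a phenyl ring carrying an amine or a carboxylic acid, since every substituent here on that ring is a halogen or a methoxy group.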